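A few compounds are considered here, and "the series" means these few. Any claim that something is new, unique, unknown or untested is made for them only; others in the source may bear on it.

Values measured in an ADME assay on HEK293 cells (Homo sapiens) for cytotoxicity, read by fluorescence and resazurin assay, with a stated time of 24 h; a lower number here means that less compound is tolerated, a higher number that more compound is tolerated:

compound 1, `O=S1(=O)C=C(Sc2nnc(-c3cccnc3)o2)c2ccccc21`: 4000 nM
compound 2, `COc1ccccc1-c1nnc(SC2=CS(=O)(=O)c3ccccc32)o1`: 3000 nM
compound 3, `O=S1(=O)C=C(Sc2nnc(-c3ccccc3Cl)o2)c2ccccc21`: 4000 nM

Compound 1 and compound 3 give the same number in this assay, and compound 2 sits within the scatter of both, so the three measured compounds cannot be told apart on these data. All three share one core and differ only in the aromatic group attached to it.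

Compound 4, `O=S1(=O)C=C(Sc2nnc(-c3ccc(Cl)cc3)o2)c2ccccc21`, is not yet measured. Compared with compound 1 it shows (4-chlorophenyl in place of pyridin-3-yl on an aromatic carbon).

Going by the values given here, two measured steps bear on this: a 1.3-fold lower number from compound 1 to compound 2 (0.12 log units; within the scatter) and no change at the digits printed from compound 1 to compound 3 (within the scatter), each replacing the same pyridin-3-yl with a substituted phenyl group without moving the number beyond the scatter. Likewise a 1.3-fold higher number from compound 2 to compound 3 (0.12 log units; within the scatter) shows that exchanging one substituent on that phenyl for another made no difference beyond the scatter. For compound 4 the expected step is therefore no change at the digits printed from compound 1 to compound 4 (within the scatter), that is, no change beyond the scatter in this assay. The estimate for compound 4 is 4000 nM, with a range from 2000 nM to 8000 nM.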

Compound 4, half-maximal cytotoxic concentration: 3000 nM
For compound 4 the middle estimate is 1.3-fold (0.12 log units) above the measured one; low and high end bracket the measured number.
By their numbers in this assay, from the lowest: compounds 2, 4, 1 and 3 (each within the scatter of the next).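

Moving the chloro group on the phenyl ring, with 4-chlorophenyl in place of 2-chlorophenyl, stays within the scatter in this assay (a 1.3-fold lower number from compound 3 to compound 4 (0.12 log units; within the scatter)). Replacing pyridin-3-yl with 4-chlorophenyl, which takes away the ring nitrogen, also stays within the scatter (a 1.3-fold lower number from compound 1 to compound 4 (0.12 log units; within the scatter)), and 4-chlorophenyl in place of 2-methoxyphenyl gives the same picture (no change at the digits printed from compound 2 to compound 4 (within the scatter)). At this aromatic carbon, the four six-membered aromatic groups shown cannot be told apart, and no supporting measurement accounts for that.

Going by these compounds, it remains open whether anything other than a six-membered aromatic ring would change the number at this place, such as a methyl group, a longer alkyl chain or a carboxylic acid. On these data alone, it is also open whether an amine on the phenyl ring would move the number beyond the scatter.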